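Shortening the aminomethyl-bearing linker on the shared core

The compounds below may be only part of what the source reports. "The series", "measured", "known", "first", "only" and "open" are said of these compounds alone.

Measured in a functional assay on CEM-CCRF cells for antagonist activity at C-X-C chemokine receptor type 4 (Homo sapiens), read by calcium flux; a lower number here means a stronger inhibitor, a higher number a weaker inhibitor:
- compound 1 `NCc1cccc(CN(Cc2nc3ccccc3[nH]2)C2CCCc3cccnc32)c1`: 1400 nM
- compound 2 `NCc1ccccc1CN(Cc1nc2ccccc2[nH]1)C1CCCc2cccnc21`: 50 nM
- compound 3 `NCC#CCN(Cc1nc2ccccc2[nH]1)C1CCCc2cccnc21`: 973 nM

Compound 3 holds the second highest of the three numbers in this assay. Its nearest neighbour is compound 1, a 1.4-fold lower number from compound 1 to compound 3 (0.16 log units; within the scatter), so the two sit within the scatter of each other. Compound 2 is far off: a 19-fold higher number from compound 2 to compound 3 (1.29 log units; beyond the scatter).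

Compound 4 `NCCN(Cc1nc2ccccc2[nH]1)C1CCCc2cccnc21` differs from compound 3 in one place: aminomethyl in place of 3-aminoprop-1-yn-1-yl on a saturated chain carbon bound to an amine nitrogen. Among the compounds with values here, no measured step shortens or lengthens this linker; the two steps that touch the same position, a 28-fold lower number from compound 1 to compound 2 (1.45 log units; beyond the scatter) and a 19-fold higher number from compound 2 to compound 3 (1.29 log units; beyond the scatter), each swap an aryl linker for another linker type and show that this position can move the number a great deal, while a 1.4-fold lower number from compound 1 to compound 3 (0.16 log units; within the scatter) shows that two quite different linkers can also land in the same range. The step from compound 3 to compound 4 is therefore weakly anchored; a modest move toward a higher number is expected for compound 4, a 2.1-fold higher number from compound 3 to compound 4 (0.31 log units; beyond the scatter). Compound 4 is estimated at 2000 nM, with a range of 400 nM to 10000 nM.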

Compound 4, half-maximal inhibitory concentration: 1370 nM
Compound 4: middle estimate off by 1.5-fold (0.16 log units), on the high side; low and high end bracket the measured number.
By their numbers in this assay, from the lowest: compound 2; then compounds 3, 4 and 1 (each within the scatter of the next).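

In this assay, replacing 3-aminoprop-1-yn-1-yl with the shorter aminomethyl gives a step within the scatter (a 1.4-fold higher number from compound 3 to compound 4 (0.15 log units; within the scatter)), so shortening this linker from compound 3 to compound 4 has no readable effect. The step from the aryl linker of compound 1 is also within the scatter (a 1.0-fold lower number from compound 1 to compound 4 (0.01 log units; within the scatter)), so compounds 1, 3 and 4 share one range despite their very different linkers, and the number does not follow linker length among these three. Compound 2 goes against any such flat picture, as its 2-(aminomethyl)phenyl group remains well apart from the short chain (a 27-fold higher number from compound 2 to compound 4 (1.44 log units; beyond the scatter)), and nothing at hand accounts for this.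

Still open, as far as these compounds go, is whether a saturated longer chain such as 3-aminopropyl or 4-aminobutyl stays in the same range. Also open, from the compounds shown here alone, is whether compound 2 keeps its number when its terminal amine is exchanged for a hydroxyl, as in 2-(hydroxymethyl)phenyl.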